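The source may report more compounds than this note shows. Statements on the series, on what has been measured and on what is new or still open speak of the compounds shown alone.

In a functional assay for agonist activity at Alpha-1D adrenergic receptor (Homo sapiens) (on this read-out lower numbers stand for an effect already at smaller amounts and higher numbers for an effect only at larger amounts of compound), compound 1, with the structure `CS(=O)(=O)c1ccc(Cl)cc1NCC1=NCCN1`, is known only as a limit, < 100000 nM, not as a measured number. Compound 3, with the structure `CS(=O)(=O)c1cccc(F)c1NCC1=NCCN1`, likewise shows only a limit in this assay, < 100000 nM. These two limits are the same, (the limit of < 100000 nM in this assay, at which 2 of the 3 values shown sit), so neither compound has a value that can be placed on the scale. Compound 2, with the structure `CSc1cc(F)ccc1NCC1=NCCN1`, is the only one of the three with a number in this assay, and compound 2 gives 9.12 nM. Compound 1 therefore stands where the numbers run out: it cannot be said to be weaker or stronger than compound 3, and against compound 2 all that can be said is that compound 2 has a value and compound 1 has none.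

The compound that follows is compound 4, with the structure `CS(=O)(=O)c1ccc(C(F)(F)F)cc1NCC1=NCCN1`. It differs from compound 1 in one place: trifluoromethyl in place of chloro on an aromatic carbon. Among the measured compounds shown here, no pair of measured compounds changes in the same place, so no measured step shows what this change does. Compound 4 carries the same methylsulfonyl group as compound 1 and compound 3, both of which gave only a limit. The expectation is therefore that compound 4 moves little, the step that the limit leaves unreadable from compound 1 to compound 4 being expected to stay near the limit. For compound 4 the estimate in this assay is 50000 nM, within the range 5000 nM to 100000 nM.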

Compound 4, half-maximal effective concentration: < 100000 nM
Compound 4: no number, only a limit; the forecaster's own chance of this, stated with the estimate: 70%; the middle value lies beyond the limit too.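

In this assay, compound 4, like compound 1, is known only as a limit and not as a number, so no step from compound 1 to compound 4 can be read: the limit of < 100000 nM in this assay, at which 3 of the 4 values shown sit.

The compounds shown leave open whether trifluoromethyl in place of chloro on an aromatic carbon changes the result in this assay at all.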